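A few compounds are considered here, and "the series" means these few. Any claim that something is new, unique, unknown or untested is made for them only; others in the source may bear on it.

Measured in a functional assay on A549 cells (Homo sapiens) for cytotoxicity, read by MTT assay, with a stated time of 72 h; on this read-out higher numbers stand for weaker inhibition and lower numbers for stronger inhibition:
compound 1 `CN(C)CCCOc1c(OCc2ccccc2)cc(O)c2c(=O)cc(-c3ccccc3)oc12` gives 2910 nM;
compound 2 `CN1CCN(CCCOc2c(OCc3ccccc3)cc(O)c3c(=O)cc(-c4ccccc4)oc23)CC1` gives 3940 nM;
compound 3 `CCN(CC)CCCCOc1c(OCc2ccccc2)cc(O)c2c(=O)cc(-c3ccccc3)oc12` gives 3910 nM.

All three share one core and differ only in the group carried on the chain. Compound 3 sits level with its neighbours: a 1.0-fold lower number from compound 2 to compound 3 (0.00 log units; within the scatter), and the gap to compound 1 also falls within the scatter. Compound 4 `CN1CCN(CCCCOc2c(OCc3ccccc3)cc(O)c3c(=O)cc(-c4ccccc4)oc23)CC1` is not yet measured; its change from compound 3 is 4-methylpiperazin-1-yl in place of diethylamino on a saturated chain carbon, four bonds along the chain from an oxygen on an aromatic ring. Among the compounds with values here, the closest precedent is the same swap made on the chain carbon three bonds from the ring oxygen, a 1.4-fold higher number from compound 1 to compound 2 (0.13 log units; within the scatter), which stayed within the scatter. No step beyond the scatter is therefore expected in this assay, and the expected step is a 1.2-fold higher number from compound 3 to compound 4 (0.06 log units; within the scatter). For compound 4 the estimate is 4500 nM, with a range from 2200 nM to 9000 nM.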

Compound 4, half-maximal inhibitory concentration: 2910 nM
Estimate against measurement, compound 4: 1.5-fold (0.19 log units) above; low and high end bracket the measured number.
By their numbers in this assay, from the lowest: compounds 1, 4, 3 and 2 (each within the scatter of the next).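

On the butyl chain, 4-methylpiperazin-1-yl in place of diethylamino gives a 1.3-fold lower number from compound 3 to compound 4 (0.13 log units; within the scatter) in this assay, so this swap now stays within the scatter on both chain lengths. Adding one chain carbon while keeping 4-methylpiperazin-1-yl gives a 1.4-fold lower number from compound 2 to compound 4 (0.13 log units; within the scatter), and the larger change gives no change at the digits printed from compound 1 to compound 4 (within the scatter), so neither step goes beyond the scatter. No supporting data bear on why these numbers stay so close.

As far as these compounds go, whether a morpholin-4-yl group, a primary amine or a longer chain would move the number beyond the scatter remains open.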